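One Stereocentre Redrawn, One Number to Go On

The compounds below may be only part of what the source reports. "The series", "measured", "known", "first", "only" and "open" are said of these compounds alone.

Among the measured compounds shown here, only one measured number is available here. In a functional assay on DU-145 cells (Homo sapiens) for inhibition, read by sulforhodamine B assay, with a stated time of 48 h (a lower number here means a stronger inhibitor of growth, a higher number a weaker inhibitor of growth), compound 2 `COc1ccc(C2([C@H]3C[C@H](n4cc(C)c(=O)[nH]c4=O)O[C@@H]3CO[Si](C)(C)C(C)(C)C)SCCCS2)cc1OC` gives 3720 nM. Compound 1 `Cc1cn([C@H]2C[C@H](CC3=CC(=O)C(=O)C=C3)[C@@H](CO[Si](C)(C)C(C)(C)C)O2)c(=O)[nH]c1=O` has no result reported, so compound 2 cannot be ranked against anything and serves only as a lone reference point.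

The next compound to consider is compound 3 `COc1ccc(C2([C@H]3C[C@@H](n4cc(C)c(=O)[nH]c4=O)O[C@@H]3CO[Si](C)(C)C(C)(C)C)SCCCS2)cc1OC`, a very close relative of compound 2: the two compounds have the same atoms and bonds and differ only in configuration as drawn: 1 of 3 stereo elements differ; a stereocentre at a saturated ring carbon is drawn R in compound 2 and S in compound 3. Nothing leaves and nothing enters. The two compounds have the same atoms and bonds, and a stereocentre at a saturated ring carbon is drawn R in compound 2 and S in compound 3. A stereocentre is a carbon whose groups can be arranged in two distinct ways in space, so the compounds differ in shape alone.

For the measured compounds named here, no measured pair shows how much such a change counts in this assay. With compound 2 at 3720 nM as the only anchor, no step beyond the scatter is expected, in either direction. The expected move is small: a 1.1-fold higher number from compound 2 to compound 3 (0.03 log units; within the scatter). Compound 3 is estimated to give 4000 nM, with an expected range from 1300 nM to 12000 nM.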

Compound 3, concentration for 50% growth inhibition: 12000 nM
For compound 3 the middle estimate is 3.0-fold (0.48 log units) below the measured one; the measured number falls inside the stated range.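

Until now there was a single number and no way to tell whether the way this saturated ring carbon is drawn matters in this assay, but the pair now gives a first size for that change: a 3.2-fold higher number from compound 2 to compound 3 (0.51 log units; beyond the scatter). The step is modest yet beyond the scatter, so this stereocentre is a place where spatial arrangement alone changes the read-out, and of these two compounds the form drawn R in compound 2 is the stronger inhibitor of growth. The step can be put down to the redrawn stereocentre and nothing else, because no atom or bond separates the pair: the fact that compounds 2 and 3 differ only in the configuration as drawn

This single pair cannot tell whether the same redrawing would have a similar size on another compound, and compound 1, with no number, adds nothing on that question. The compounds shown also leave open how the stereocentre would count if the silyl-protected oxygen were replaced by a free hydroxyl group or an amine, or if the sulfur-containing ring gave way to a simple carbonyl.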